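Fluorine position on the phenoxy group in one series

The source may hold more compounds than are shown below. What is called first, only, known or untested is meant among the compounds shown, and "the series" means these compounds.

The series is read in a functional assay on HEK293 cells for positive allosteric modulation of metabotropic glutamate receptor 5 (Homo sapiens), read by calcium flux; on this read-out higher numbers stand for larger maximal responses and lower numbers for smaller maximal responses. Compound 1 `O=C1c2cc(COc3ccccc3)nn2CCN1c1cccnc1` gives 64% in this assay. Compound 2 `O=C1c2cc(COc3ccccc3F)nn2CCN1c1ccc(F)cc1` gives 66% in this assay; compound 1 and compound 2 lie within the scatter of each other, so the two numbers cannot be ranked. Compound 3 `O=C1c2cc(COc3ccc(F)cc3)nn2CCN1c1ccc(F)cc1` is not yet measured in this assay. It differs from compound 2 in one place: 4-fluorophenyl in place of 2-fluorophenyl on an oxygen on a saturated carbon. Among the measured compounds shown here, no step between measured compounds covers this change, and nothing in the two values known so far points in either direction for it. The working expectation is a step from compound 2 to compound 3 of a number 1 percentage points lower from compound 2 to compound 3 (within the scatter) in this assay, that is, none beyond the scatter. Compound 3 is therefore estimated at 65% in this assay, with a range from 50% to 80%.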

Compound 3, largest response reached (Emax), in percent of the reference or control that the assay uses: 72%
Compound 3: the middle estimate sits 7 percentage points below what was measured; the range from low to high includes it.
By their numbers in this assay, from the lowest: compounds 1, 2 and 3 (each within the scatter of the next).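

In this assay, among the compounds shown here, the exchange of 2-fluorophenyl for 4-fluorophenyl on an oxygen on a saturated carbon gives a number 6 percentage points higher from compound 2 to compound 3 (within the scatter) and is the first single-place reading at this position. The maximal response is kept with the fluorine in either placing, and the two isomers cannot be ranked on this read-out. No measurement at hand bears on what lies behind the values of these two compounds.

The reading covers only fluorine on this phenyl ring, so a chlorophenyl, a methoxyphenyl or a saturated cyclohexyl in the same place remains an open test of how far the position can be changed. Also open, on these data alone, is whether an amine in place of the ether oxygen would keep the response, and how the 4-fluorophenoxy group behaves with a pyridine in place of the 4-fluorophenyl on the core.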